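The source may hold more compounds than are shown below. What is called first, only, known or untested is meant among the compounds shown, and "the series" means these compounds.

In a functional assay on HT-29 cells (Homo sapiens) for antiproliferative activity, read by sulforhodamine B assay, with a stated time of 48 h (on this read-out lower numbers stand for stronger inhibition and higher numbers for weaker inhibition), the measured compounds read:
compound 1 `Cc1ccc(NS(=O)(=O)c2ccc(N3CCNC3=O)cc2)cc1` gives 480 nM
compound 2 `O=C1NCCN1c1ccc(S(=O)(=O)Nc2ccc(F)cc2)cc1` gives 370 nM
compound 3 `O=C1NCCN1c1ccc(S(=O)(=O)Nc2ccccc2)cc1` gives 280 nM

Compound 3 (280 nM) lies within the scatter of compound 1 and compound 2. Compound 4 `O=C1NCCN1c1ccc(S(=O)(=O)Nc2cccc(Br)c2)cc1` has bromo in place of hydrogen on an aromatic carbon, meta to a large group (bromo in place of hydrogen on an aromatic carbon). The nearest evidence is a 1.7-fold lower number from compound 1 to compound 3 (0.23 log units; within the scatter) and a 1.3-fold lower number from compound 2 to compound 3 (0.12 log units; within the scatter) (both swaps on the same phenyl ring, both within the scatter). Going by the values given here, no bromo compound has been measured, so neither step transfers exactly. In this assay no step beyond the scatter is expected, and no direction can be assigned with confidence. The expected step is a 1.3-fold higher number from compound 3 to compound 4 (0.10 log units; within the scatter) (an estimate). For compound 4 the estimated value is 350 nM (expected range 130 nM to 900 nM).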

Compound 4, half-maximal inhibitory concentration: 77 nM
Estimate against measurement, compound 4: 4.5-fold (0.66 log units) above; measured number outside the range, below it.
By their numbers in this assay, from the lowest: compound 4; then compounds 3, 2 and 1 (each within the scatter of the next).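

In this assay, bromo on an aromatic carbon, meta to a large group, gives a 3.6-fold lower number from compound 3 to compound 4 (0.56 log units; beyond the scatter) and so moves the number beyond the scatter, which no swap among compounds 1, 2 and 3 did. The 3-bromophenyl group also stands apart from the 4-fluorophenyl group, with a 4.8-fold lower number from compound 2 to compound 4 (0.68 log units; beyond the scatter), and from the 4-methylphenyl group, with a 6.2-fold lower number from compound 1 to compound 4 (0.79 log units; beyond the scatter). No measurement at hand accounts for this step.

As far as these compounds go, whether the step is particular to bromo stays open: chloro, iodo or an amine on the same carbon would bear on that.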